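Benzazole variation on the biaryl urea series

The compounds below may be only part of what the source reports. "The series", "measured", "known", "first", "only" and "open" are said of these compounds alone.

Measured so far:
compound 1, `CC(C)(C)c1cc(NC(=O)Nc2ccc(-c3cc4ccccc4s3)cc2)no1` — > 900 nM in a functional assay on MV4-11 cells (Homo sapiens) for cytotoxicity, read by MTT assay, with a stated time of 72 h; on this read-out lower numbers stand for stronger inhibition and higher numbers for weaker inhibition
compound 2, `CC(C)(C)c1cc(NC(=O)Nc2ccc(-c3nc4ccccc4o3)cc2)no1` — 82.6 nM in this assay

Compound 1 reaches only a limit of the assay, > 900 nM, and no number. Among the measured compounds shown here, compound 2, with 82.6 nM, holds the only numerical value shown. The other entry, that of compound 1, is a limit (the limit of > 900 nM in this assay, at which 1 of the 2 values shown sits). For the measured compounds named here, the one measured step, an at least 10-fold lower number from compound 1 to compound 2 (1.03 log units; beyond the scatter), is the sole guide for the next change.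

Compound 3, `CC(C)(C)c1cc(NC(=O)Nc2ccc(-c3nc4ccccc4s3)cc2)no1`, is not yet measured. It differs from compound 2 by 1,3-benzothiazol-2-yl in place of 1,3-benzoxazol-2-yl on an aromatic carbon. This exchange does not repeat the measured step: compound 1 to compound 2 replaced a 1-benzothiophen-2-yl group by 1,3-benzoxazol-2-yl, whereas here the 1,3-benzoxazol-2-yl group gives way to 1,3-benzothiazol-2-yl, which shares its 1,3-arrangement of hetero atoms with the group it replaces. The large step already seen therefore bears only indirectly; a smaller step is expected, in either direction, and most likely within the scatter. For compound 3 the expected step is a 1.6-fold higher number from compound 2 to compound 3 (0.20 log units; within the scatter). Compound 3 is estimated at 130 nM, ranging from 35 nM to 500 nM.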

Compound 3, half-maximal inhibitory concentration: 172 nM
Compound 3: the middle estimate sits 1.3-fold (0.12 log units) below what was measured; measured number inside the range.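

The 1,3-benzothiazol-2-yl and 1,3-benzoxazol-2-yl groups are not interchangeable at this position, on an aromatic carbon para to a large group: in this assay the exchange gives a 2.1-fold higher number from compound 2 to compound 3 (0.32 log units; beyond the scatter), a modest step. Compound 3 also carries sulfur in its five-membered ring, as compound 1 does, yet the exchange of 1-benzothiophen-2-yl for 1,3-benzothiazol-2-yl gives an at least 5.2-fold lower number from compound 1 to compound 3 (0.71 log units; beyond the scatter), so among the three compounds the two groups with a ring nitrogen go with the lower numbers, and sulfur in that ring does not by itself go with a value at the limit. The value of compound 1 is a limit of the assay, so this last step marks a bound and not an exact size: the limit of > 900 nM in this assay, at which 1 of the 3 values shown sits.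

The compounds shown leave open how a benzimidazol-2-yl group, with a hydrogen on a ring nitrogen, would compare with these groups at the same position. They also leave open whether the fused carbon ring is needed at all, a question that a plain oxazol-2-yl group would address.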